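The source may report more compounds than this note shows. Statements on the series, on what has been measured and on what is new or still open speak of the compounds shown alone.

Compound 1 `N=C(NO)N/N=C/c1ccccc1Cl` and compound 2 `N=C(NO)N/N=C/c1ccc(Cl)cc1` were both examined in an ADME assay on HeLa cells (Homo sapiens) for cytotoxicity; a lower number here means that less compound is tolerated, a higher number that more compound is tolerated. In this assay compound 1 gives > 100000 nM, which is a limit of the assay rather than a number. Compound 2 likewise gives > 100000 nM in this assay, again only a limit. Within the data shown here, compound 2 therefore stands at the same boundary as the one other value shown, and both sit at the limit of > 100000 nM in this assay, at which 2 of the 2 values shown sit.

Compound 3 `CN(C)c1ccc(/C=N/NC(=N)NO)cc1` has not yet been measured. It differs from compound 2 by dimethylamino in place of chloro on an aromatic carbon. Among the measured compounds shown here, no measured step between two compounds exists, so the size of the change in this assay cannot be read from the data; the two values shown only set a floor. The step of a number no higher from compound 2 to compound 3 (the limit leaves the size open) is expected to be none beyond the scatter. Compound 3 is accordingly estimated at 100000 nM, within a range of 30000 nM to 300000 nM.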

Compound 3, half-maximal cytotoxic concentration: > 100000 nM
Compound 3 ended at the assay's limit; the forecaster's own chance of this, stated with the estimate: 70%; the middle value lies on the limit itself.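

No step from compound 2 to compound 3 can be read in this assay, as neither compound gives a number, only a limit: the limit of > 100000 nM in this assay, at which 3 of the 3 values shown sit.

The compounds shown leave open whether dimethylamino in place of chloro on an aromatic carbon changes tolerance in this assay at all.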